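The compounds below may be only part of what the source reports. "The series", "measured", "known", "first", "only" and "open" are said of these compounds alone.

Compound 1 `CN(C)c1cc2[nH]c(C3CCCCC3)nc2cc1NC(=O)OCc1ccccc1` was examined in an ADME assay on Vero cells (Chlorocebus sabaeus) for cytotoxicity, read by resazurin assay, with a stated time of 3 days; on this read-out higher numbers stand for weaker inhibition and lower numbers for stronger inhibition. In this assay compound 1 gives > 100 ug/mL, which is a limit of the assay rather than a measured number. Compound 2 `CCCN(CCC)c1cc2[nH]c(C3CCCCC3)nc2cc1NC(=O)OCc1ccccc1` differs from it by carrying dipropylamino in place of dimethylamino on an aromatic carbon. In this assay compound 2 gives > 100 ug/mL, again a limit of the assay and not a number. The step that the two limits leave unreadable from compound 1 to compound 2 therefore cannot be read, because it rests on (the limit of > 100 ug/mL in this assay, at which 2 of the 2 values shown sit). Compound 3 `CCCCNC(=O)Nc1cc2nc(C3CCCCC3)[nH]c2cc1N(C)C` is not yet measured; it differs from compound 1 by butylamino in place of benzyloxy on a carbonyl carbon. Among the compounds with values here, no measured step touches the carbonyl carbon, so the only guidance is that every value seen so far rests at the limit of this assay. For compound 3 the expected outcome in this assay is therefore no step beyond the scatter, a number no higher from compound 1 to compound 3 (the limit leaves the size open), with another limit the likeliest report. Compound 3 is estimated at 100 ug/mL, with a range from 40 ug/mL to 250 ug/mL.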

Compound 3, half-maximal inhibitory concentration: > 100 ug/mL
Compound 3: no number, only a limit; the forecaster's own chance of this, stated with the estimate: 75%; the middle value sits exactly at the limit.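

Within the data shown here, compound 3 gives only a limit of the assay, as compound 1 does, so no step from compound 1 to compound 3 can be read, because the result rests on this: the limit of > 100 ug/mL in this assay, at which 3 of the 3 values shown sit. The compounds shown leave open whether butylamino in place of benzyloxy changes the read-out in this assay at all.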